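The source may hold more compounds than are shown below. What is called first, only, known or untested is meant among the compounds shown, and "the series" means these compounds.

In a functional assay on RPMI 8402 cells (Homo sapiens) for cytotoxicity (a higher number here means a weaker inhibitor, a lower number a stronger inhibitor), compound 1 `N#Cc1ccc2[nH]c(-c3ccc4[nH]c(-c5ccccc5)nc4c3)nc2c1` stands at > 25000 nM, which is a limit of the assay and not a number. Compound 4 `CN1CCN(c2ccc3[nH]c(-c4ccc5[nH]c(-c6ccccc6)nc5c4)nc3c2)CC1` carries 4-methylpiperazin-1-yl in place of cyano on an aromatic carbon of compound 1: 4-methylpiperazin-1-yl in place of cyano on an aromatic carbon. Among the measured compounds shown here, no measured step makes this change. Compound 2 `Cc1cccc(-c2nc3cc(-c4nc5cc(C#N)ccc5[nH]4)ccc3[nH]2)c1` gives 860 nM and compound 3 `N#Cc1ccc2[nH]c(-c3ccc4[nH]c(-c5cccc6ccccc56)nc4c3)nc2c1` gives 650 nM. Both keep the cyano group and differ from compound 1 at its phenyl group. Their large steps, an at least 29-fold lower number from compound 1 to compound 2 (1.46 log units; beyond the scatter) and an at least 38-fold lower number from compound 1 to compound 3 (1.58 log units; beyond the scatter), show that compound 1 can move far with a single change elsewhere, so the guide is only indirect. A large step towards a lower number is expected in this assay, an at least 25-fold lower number from compound 1 to compound 4 (1.39 log units; beyond the scatter). Compound 4 is estimated at 1000 nM, within 150 nM to 8000 nM.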

Compound 4, half-maximal inhibitory concentration: 490 nM
The estimate for compound 4 lay 2.0-fold (0.31 log units) above the measured number; the measured number falls inside the stated range.
By their numbers in this assay, from the lowest: compounds 4, 3 and 2 (each within the scatter of the next). At a limit, above all of these: compound 1.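

In this assay, among the compounds shown here, the earlier steps changed only the phenyl group and kept the nitrile, whereas the cyano position itself now proves open to change. Putting 4-methylpiperazin-1-yl in place of cyano on this aromatic carbon gives an at least 51-fold lower number from compound 1 to compound 4 (1.70 log units; beyond the scatter), so a lower number is reached with the phenyl group untouched. The value of compound 1 is a limit and not a number: the limit of > 25000 nM in this assay, at which 1 of the 4 values shown sits.

On these data alone, whether an open-chain amine such as dimethylamino or a carboxylic acid would serve at this position stays open. Also open, as far as these compounds go, is whether 4-methylpiperazin-1-yl combines with a methyl on the phenyl group, or with naphthalen-1-yl in its place.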